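Working notes on cytotoxicity: from compound 2 to compound 4

The source may report more compounds than this note shows. Statements on the series, on what has been measured and on what is new or still open speak of the compounds shown alone.

Of the compounds shown here, three of the shared core have been measured in a functional assay on HEK293 cells (Homo sapiens) for cytotoxicity; on this read-out higher numbers stand for lower toxicity in this test and lower numbers for higher toxicity in this test: compound 1 `COc1ccc([C@H]2CC(=O)N(c3ccc(N)cc3)C2)cc1OC1CCCC1`, compound 2 `COc1ccc([C@H]2CC(=O)N(c3cccc(C(F)(F)F)c3)C2)cc1OC1CCCC1` and compound 3 `COc1ccc([C@H]2CC(=O)N(c3ccc(S(C)(=O)=O)cc3)C2)cc1OC1CCCC1`. In this assay compound 1 gives > 10000 nM, which is a limit of the assay and not a number. In this assay compound 2 gives > 10000 nM, again a limit. In this assay compound 3 gives > 10000 nM, also a limit. Compound 2 therefore stands where every measured value of the series stands, as recorded in the limit of > 10000 nM in this assay, at which 3 of the 3 values shown sit. The steps a step that the two limits leave unreadable from compound 1 to compound 2, a step that the two limits leave unreadable from compound 1 to compound 3 and a step that the two limits leave unreadable from compound 2 to compound 3 are all unreadable, each running between two limits.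

Compound 4 `COc1ccc([C@H]2CC(=O)N(c3cccc(NS(=O)(=O)c4ccccc4Cl)c3)C2)cc1OC1CCCC1` differs from compound 2 as follows: ((2-chlorophenyl)sulfonyl)amino in place of trifluoromethyl on an aromatic carbon. Going by the values given here, none of the measured steps can be read, so none gives a size to carry over; the three values together show only that the groups tried so far on the amide-type nitrogen in the ring have left no measurable toxicity in this assay. For compound 4 the step of a number no higher from compound 2 to compound 4 (the limit leaves the size open) is therefore expected to be none beyond the scatter. Compound 4 is estimated at 10000 nM in this assay, within 3000 nM to 40000 nM.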

Compound 4, half-maximal cytotoxic concentration: > 10000 nM
Compound 4 gave a limit, no number; the forecaster's own chance of this, stated with the estimate: 75%; the middle value sits exactly at the limit.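

In this assay compound 4 gives > 10000 nM, which is a limit of the assay and not a number. Compound 2 and compound 4 both stand at a limit, so no size can be read for the step between them, and the series stays as it was: the limit of > 10000 nM in this assay, at which 4 of the 4 values shown sit.

The compounds shown leave open at what concentration, if any, toxicity would appear in this assay, and whether the groups tried on the shared core differ at all.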